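A few compounds are considered here, and "the series" means these few. Any claim that something is new, unique, unknown or untested is made for them only; others in the source may bear on it.

Three compounds with a shared core have numbers in a functional assay on MCF7 cells (Homo sapiens) for inhibition, with a stated time of 72 h; on this read-out lower numbers stand for stronger inhibition and higher numbers for weaker inhibition. Compound 1 (`NC1CCC(Nc2nc(NCc3ccc(Br)cc3)c3ncn(C4CCCC4)c3n2)CC1`) gives 850 nM, compound 2 (`NC1CCC(Nc2nc(NCc3ccc(-c4ccco4)cc3)c3ncn(C4CCCC4)c3n2)CC1`) gives 85 nM, and compound 3 (`NC1CCC(Nc2nc(NCc3ccc(-c4ccccc4)nc3)c3ncn(C4CCCC4)c3n2)CC1`) gives 483 nM. Compound 3 cannot be told apart from compound 1, as the data show a 1.8-fold lower number from compound 1 to compound 3 (0.25 log units; within the scatter). Compound 2 is the strongest of the three, and the record shows a 5.7-fold higher number from compound 2 to compound 3 (0.75 log units; beyond the scatter).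

Compound 4 (`NC1CCC(Nc2nc(NCc3ccc(-c4cccc(F)c4)nc3)c3ncn(C4CCCC4)c3n2)CC1`) differs from compound 3 in one place: fluoro in place of hydrogen on an aromatic carbon, which turns phenyl into 3-fluorophenyl (fluoro in place of hydrogen on an aromatic carbon). Among the compounds with values here, no measured step makes this same change. The nearest in kind is a 10-fold lower number from compound 1 to compound 2 (1.00 log units; beyond the scatter), also a swap on an aromatic carbon, but there a bromo gives way to a whole furan-2-yl ring, a much larger exchange than one fluoro for one hydrogen. The other two steps exchange larger groups still, so they show only the spread of numbers in this small set.

For so small a change, no step beyond the scatter is expected in this assay, and these data support no firm direction. The estimated step is a 1.2-fold lower number from compound 3 to compound 4 (0.06 log units; within the scatter). For compound 4 the estimated value is 420 nM, with an expected range from 180 nM to 950 nM.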

Compound 4, half-maximal inhibitory concentration: 33 nM
Beside the measured number, compound 4's estimate is 13-fold (1.10 log units) above it; the measured number lies below the stated range.
By their numbers in this assay, from the lowest: compound 4; then compound 2; then compounds 3 and 1 (each within the scatter of the next).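

Turning phenyl into 3-fluorophenyl gives a 15-fold lower number from compound 3 to compound 4 (1.17 log units; beyond the scatter) in this assay, so a change of one heavy atom, with no ring and no hydrogen-bond donor or acceptor, can move this read-out by a large step. Among the earlier compounds, a step beyond the scatter came with the exchange of a whole group, as with furan-2-yl for bromo in a 10-fold lower number from compound 1 to compound 2 (1.00 log units; beyond the scatter), whereas this pair shows that a single aromatic carbon, meta to a large group, is itself sensitive to substitution. The data shown give no cause for this step.

On these data alone, this is one pair, so it remains open whether the gain belongs to fluoro in particular or would also appear with chloro, methyl or methoxy on the same carbon. As far as these compounds go, it is equally open whether fluoro on the other carbons of this six-membered aromatic ring would give a step of similar size, or whether the same change would carry over to compounds with a different group on the shared core.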